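A few compounds are considered here, and "the series" means these few. Any claim that something is new, unique, unknown or untested is made for them only; others in the source may bear on it.

Compound 1 `COc1c(OCCCN2CCCC2)cc2oc(-c3ccccc3)cc(=O)c2c1O` is the starting point. Within the data shown here, in a functional assay on HCT-116 cells (Homo sapiens) for antiproliferative activity, read by MTT assay, with a stated time of 48 h (a lower number here means a stronger inhibitor, a higher number a weaker inhibitor), compound 1 gives 26600 nM, the second highest of the three numbers measured so far. Compound 2 `COc1c(OCCCN2CCN(C)CC2)cc2oc(-c3ccccc3)cc(=O)c2c1O` gives 42500 nM, and compound 3 `COc1c(OCCCCN2CCCCC2)cc2oc(-c3ccccc3)cc(=O)c2c1O` gives 3000 nM. Compound 4 `COc1c(OCCCCN2CCN(C)CC2)cc2oc(-c3ccccc3)cc(=O)c2c1O` has not yet been measured; relative to compound 1 it carries (4-methylpiperazin-1-yl)methyl in place of pyrrolidin-1-yl on a saturated chain carbon, three bonds along the chain from an oxygen on an aromatic ring. Among the measured compounds shown here, two measured steps bear on this change. Exchanging the ring alone, pyrrolidin-1-yl for 4-methylpiperazin-1-yl, gave a 1.6-fold higher number from compound 1 to compound 2 (0.20 log units; within the scatter). Moving to (piperidin-1-yl)methyl gave an 8.9-fold lower number from compound 1 to compound 3 (0.95 log units; beyond the scatter). Compound 4 combines both: the 4-methylpiperazin-1-yl ring set one bond further out, as the piperidin-1-yl ring is in compound 3. A modest lowering is therefore expected, somewhat short of what compound 3 showed because compound 2 gave a 1.6-fold higher number from compound 1 to compound 2 (0.20 log units; within the scatter), which leaned the other way. For compound 4 the estimated value in this assay is 4800 nM, with a range from 1500 nM to 15000 nM. The expected step is a 5.5-fold lower number from compound 1 to compound 4 (0.74 log units; beyond the scatter).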

Compound 4, half-maximal inhibitory concentration: 12500 nM
For compound 4 the middle estimate is 2.6-fold (0.42 log units) below the measured one; the range from low to high includes it.
By their numbers in this assay, from the lowest: compound 3; then compound 4; then compounds 1 and 2 (each within the scatter of the next).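

In this assay, among these compounds, keeping the 4-methylpiperazin-1-yl ring and changing only the chain to the longer one gives a 3.4-fold lower number from compound 2 to compound 4 (0.53 log units; beyond the scatter), the first step here that isolates chain length. On that longer chain the ring also matters: 4-methylpiperazin-1-yl in place of piperidin-1-yl gives a 4.2-fold higher number from compound 3 to compound 4 (0.62 log units; beyond the scatter), so the longer chain alone does not carry the full lowering seen for compound 3. The two changes together leave a smaller net shift, a 2.1-fold lower number from compound 1 to compound 4 (0.33 log units; beyond the scatter), with the ring exchange offsetting part of what the chain provides.

Nothing available explains why the ring matters on the longer chain. Still open, from the compounds shown here alone, is how a morpholine ring, or a chain longer again, would behave at this position.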